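Shortening a Side Chain of Compound 2

A few compounds are considered here, and "the series" means these few. Any claim that something is new, unique, unknown or untested is made for them only; others in the source may bear on it.

Measured in a functional assay on MIA PaCa-2 cells (Homo sapiens) for inhibition, read by MTT assay, with a stated time of 24 h; on this read-out higher numbers stand for weaker inhibition of growth and lower numbers for stronger inhibition of growth:
- compound 1 `N[C@@H](CC(=O)OC[C@H]1O[C@@H](n2cc(F)c(=O)[nH]c2=O)C[C@@H]1OC(=O)C[C@H](N)C(=O)O)C(=O)O`: 2000000 nM
- compound 2 `N[C@@H](CCC(=O)O[C@H]1C[C@H](n2cc(F)c(=O)[nH]c2=O)O[C@@H]1CO)C(=O)O`: 2500000 nM

Compound 2, at 2500000 nM, stands within the usual scatter of compound 1, so these two values cannot be told apart. Compound 3 `N[C@@H](CC(=O)O[C@H]1C[C@H](n2cc(F)c(=O)[nH]c2=O)O[C@@H]1CO)C(=O)O` is not yet measured. It differs from compound 2 by one change: amino(carboxy)methyl in place of 2-amino-2-carboxyethyl on a saturated chain carbon bound to a carbonyl carbon. Among the measured compounds shown here, no measured pair isolates this change, so the evidence is thin. Compound 1 also carries amino(carboxy)methyl and gives 2000000 nM. The estimated step of a 1.1-fold lower number from compound 2 to compound 3 (0.06 log units; within the scatter) is therefore expected to stay within the scatter, in neither direction. For compound 3, the expected value in this assay is 2200000 nM, with an estimated range of 1000000 nM to 5000000 nM.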

Compound 3, concentration for 50% growth inhibition: 4100000 nM
The estimate for compound 3 lay 1.9-fold (0.27 log units) below the measured number; measured number inside the range.
By their numbers in this assay, from the lowest: compounds 1, 2 and 3 (each within the scatter of the next, the first and the last beyond it).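

Shortening the side chain, with amino(carboxy)methyl in place of 2-amino-2-carboxyethyl on a saturated chain carbon bound to a carbonyl carbon, gives a 1.6-fold higher number from compound 2 to compound 3 (0.21 log units; within the scatter), so these two chain lengths cannot be told apart in this assay. A step beyond the scatter appears only with hydrogen in place of (2-amino-2-carboxyethyl)carbonyl on an oxygen on a saturated carbon, which gives a 2.1-fold higher number from compound 1 to compound 3 (0.31 log units; beyond the scatter), a modest loss of growth inhibition. Nothing available here explains either step.

From the compounds shown here alone, whether a chain longer than 3-amino-3-carboxypropyl, or one ending in an amine with no carboxylic acid, would shift the number remains open. Also open, going by these compounds, is whether an amide in place of the ester link would behave any differently at this position.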